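The compounds below may be only part of what the source reports. "The series", "measured", "known", "first", "only" and "open" are said of these compounds alone.

Compound 1 `COc1ccc(CNc2nc([Se]C)nc3ccccc23)cc1` is examined in a functional assay on HT-29 cells (Homo sapiens) for cytotoxicity, read by MTT assay, with a stated time of 72 h; on this read-out lower numbers stand for stronger inhibition of growth and higher numbers for weaker inhibition of growth. In this assay compound 1 gives > 100000 nM, which is a limit of the assay rather than a measured number. Compound 2 `COc1ccc(CNc2nc([SeH])nc3ccccc23)cc1` differs from it by hydrogen in place of methyl on a selenium. In this assay compound 2 gives > 100000 nM, again a limit. The step from one to the other is a step that the two limits leave unreadable from compound 1 to compound 2. Compound 3 `[SeH]c1nc([SeH])c2ccccc2n1`, a smaller relative of the shared core, gives 45200 nM in this assay. the limit of > 100000 nM in this assay, at which 2 of the 3 values shown sit, marks where most of these values sit.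

Compound 4 `C[Se]c1nc(NCc2ccccc2)c2ccccc2n1` differs from compound 1 by hydrogen in place of methoxy on an aromatic carbon, para to a large group. Within the data shown here, no measured step covers this change, and compound 1 itself shows only a limit. Compound 4 is therefore expected to give around 150000 nM in this assay, somewhere within 40000 nM to 600000 nM. The expected step is a step that the limit leaves unreadable from compound 1 to compound 4.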

Compound 4, concentration for total growth inhibition: 81000 nM
Beside the measured number, compound 4's estimate is 1.9-fold (0.27 log units) above it; measured number inside the range.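

Compound 1 gives > 100000 nM in this assay, a limit of the assay and not a number. Hydrogen in place of methoxy on this aromatic carbon, para to a large group, yields a measured number, and the change reads as an at least 1.2-fold lower number from compound 1 to compound 4 (0.09 log units; that floor lies within the scatter), so its true size stays uncertain. Limits still mark much of this small set: the limit of > 100000 nM in this assay, at which 2 of the 4 values shown sit.

The compounds shown leave open how a chlorine or an amine on the same aromatic carbon would read. They also leave open what a longer chain in place of the methyl on selenium would do.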